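The compounds below may be only part of what the source reports. "The series", "measured", "known", "first", "only" and "open" are said of these compounds alone.

Compound 1, `CCCCNc1nc(N)c2nc(O)n(Cc3ccccc3)c2n1`, gives 0.1 mg/kg in a functional assay on the whole organism for activation, with Mus musculus as the target; on this read-out lower numbers stand for an effect already at smaller amounts and higher numbers for an effect only at larger amounts of compound. Compound 2, `Nc1ncnc2c1nc(O)n2Cc1ccccc1`, gives 30 mg/kg in this assay.

Within the data shown here, compound 2 has the highest of the two numbers; the only known step, a 300-fold higher number from compound 1 to compound 2 (2.48 log units; beyond the scatter), comes from hydrogen in place of butylamino on an aromatic carbon. Compound 3, `COc1nc(N)c2nc(O)n(Cc3ccccc3)c2n1`, changes that same aromatic carbon, with methoxy in place of hydrogen on an aromatic carbon. Since that step was large and methoxy again fills the place that hydrogen left, a step downward in this assay is expected, though smaller, and a 6.0-fold lower number from compound 2 to compound 3 (0.78 log units; beyond the scatter) is the estimate. Compound 3 is therefore expected to give about 5 mg/kg, within a range of 1 mg/kg to 30 mg/kg.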

Compound 3, minimum effective dose: > 1 mg/kg
Compound 3 was reported as a limit; the forecaster's own chance of this, stated with the estimate: 10%; the middle value does not contradict the limit.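

In this assay, compound 3 is reported only as a limit: the limit of > 1 mg/kg in this assay, at which 1 of the 3 values shown sits. Even so, this carbon between two ring nitrogen atoms clearly distinguishes butylamino from methoxy, with an at least 10-fold higher number from compound 1 to compound 3 (1.00 log units; beyond the scatter). On these data alone, the step from compound 2 cannot be read, so it remains unknown whether methoxy offers any gain over hydrogen.

Methoxy differs from butylamino in both its linking atom and its chain length, so the compounds shown cannot separate these two features. A butoxy chain or a shorter ethylamino chain at this carbon would address that question.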